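The source may report more compounds than this note shows. Statements on the series, on what has been measured and on what is new or still open speak of the compounds shown alone.

Three compounds have been measured in a functional assay on A2780 cells (Homo sapiens) for inhibition, read by sulforhodamine B assay, with a stated time of 72 h; on this read-out higher numbers stand for weaker inhibition and lower numbers for stronger inhibition:

- compound 1 `O=C(NCc1ccc(S(=O)(=O)c2ccccc2)cc1)c1c[nH]c2ccncc12` gives 2100 nM
- compound 2 `O=C(NCc1ccc(S(=O)(=O)c2cccc(C(F)(F)F)c2)cc1)c1cnc2nccn2c1` gives 2 nM
- compound 3 `O=C(NCc1ccc(S(=O)(=O)c2ccccc2)cc1)c1cc2cnccc2[nH]1` gives 18 nM

Compound 3 stands in the middle of these numbers, higher than compound 2 and lower than compound 1. The next compound, compound 4 `O=C(NCc1ccc(S(=O)(=O)c2ccccc2)cc1)c1cnc2nccn2c1`, keeps all of compound 3 except the group on the carbonyl carbon. The difference is a group of 9 heavy atoms (6 carbon, 3 nitrogen; one five-membered aromatic ring with 2 hetero atoms, one six-membered aromatic ring with 2 hetero atoms) in place of a group of 9 heavy atoms (7 carbon, 2 nitrogen; one five-membered aromatic ring with 1 hetero atom, one six-membered aromatic ring with 1 hetero atom), on a carbonyl carbon.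

For the measured compounds named here, only one measured step concerns that same place, and it is large: a 120-fold lower number from compound 1 to compound 3 (2.07 log units; beyond the scatter). It shows that the number can move strongly when one group of this size replaces another here, but it gives no direction for the new group. Compound 2 is the closer guide. It carries the group that enters in compound 4, and compound 2 gives 2 nM. However, it also carries a trifluoromethyl group that compound 4 lacks, and no measured pair separates the two changes. A modest move to a lower number is therefore expected, possibly one that stays within the scatter, with a wide margin on both sides. The expected change is a 1.8-fold lower number from compound 3 to compound 4 (0.26 log units; within the scatter). For compound 4 the estimated value is 10 nM, with an expected range from 3 nM to 40 nM.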

Compound 4, half-maximal inhibitory concentration: 68 nM
The estimate for compound 4 lay 6.8-fold (0.83 log units) below the measured number, outside the stated range (above it).
By their numbers in this assay, from the lowest: compound 2; then compound 3; then compound 4; then compound 1.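

In this assay the exchange on the carbonyl carbon now has a direction for the group that enters in compound 4: it gives a 3.8-fold higher number from compound 3 to compound 4 (0.58 log units; beyond the scatter) but also a 31-fold lower number from compound 1 to compound 4 (1.49 log units; beyond the scatter), so among the three groups compared on this carbonyl carbon, the new one ranks behind the group of compound 3 and ahead of the group of compound 1. The other change can now be read alone: hydrogen in place of trifluoromethyl on an aromatic carbon gives a 34-fold higher number from compound 2 to compound 4 (1.53 log units; beyond the scatter), which means that much of the low number of compound 2 goes with the trifluoromethyl group and not with the group on the carbonyl carbon. Nothing given here explains either step.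

From the compounds shown here alone, whether trifluoromethyl lowers the number to a similar extent when the group of compound 3 or compound 1 sits on the carbonyl carbon remains open, since the size of that step is known for one group only. Also open, going by these compounds, is how a chlorine atom or a methoxy group would compare with trifluoromethyl on that aromatic carbon.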